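Amide substituent change on compound 1: working notes

This account rests on a few compounds, and the source may have more. Where it says the series, first, only, none or still open, it means among the compounds named here.

Measured in a functional assay on HepG2 cells (Homo sapiens) for antiproliferative activity, read by MTT assay, with a stated time of 48 h; on this read-out higher numbers stand for weaker inhibition and lower numbers for stronger inhibition:
compound 1 `CCn1c(C(=O)NCCCN(C)C)ccc1C(CC)(CC)c1ccc(OCCC(O)(CC)CC)c(C)c1` gives 110 nM.
compound 2 `C=CCN(C)C(=O)c1ccc(C(CC)(CC)c2ccc(OCCC(O)(CC)CC)c(C)c2)n1CC` gives > 50000 nM, a limit of the assay.

Among the measured compounds shown here, compound 1 stands with the only actual number in this assay; the other entry is a limit. For the measured compounds named here, the single step measured between compounds differing in one place is an at least 450-fold higher number from compound 1 to compound 2 (2.65 log units; beyond the scatter), which runs up to the limit of > 50000 nM in this assay, at which 1 of the 2 values shown sits.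

Compound 3 `CCn1c(C(=O)NC(CC(=O)O)C(=O)OC)ccc1C(CC)(CC)c1ccc(OCCC(O)(CC)CC)c(C)c1` differs from compound 1 as a group of 9 heavy atoms (5 carbon, 4 oxygen; no ring) in place of a group of 6 heavy atoms (5 carbon, 1 nitrogen; no ring), on an amide-type nitrogen. The 3-(dimethylamino)propyl group leaves in both changes, so the measured step that bears on compound 3 is an at least 450-fold higher number from compound 1 to compound 2 (2.65 log units; beyond the scatter), a large loss. The group entering compound 3 is not the allyl(methyl)amino of compound 2, so the size is uncertain, but a large step in the same direction is expected in this assay. The step from compound 1 is expected to be a 140-fold higher number from compound 1 to compound 3 (2.13 log units; beyond the scatter). For compound 3 the estimated value in this assay is 15000 nM, between 2000 nM and 50000 nM, with a fair chance that only a limit is reported.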

Compound 3, half-maximal inhibitory concentration: 10700 nM
Compound 3: middle estimate off by 1.4-fold (0.15 log units), on the high side, and the stated range covers the measured number.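

Series notes on the amide substituent: in this assay, a second replacement of the 3-(dimethylamino)propyl group on the amide-type nitrogen also gives a large loss, with a 97-fold higher number from compound 1 to compound 3 (1.99 log units; beyond the scatter), so among the compounds shown the loss is not confined to the allyl(methyl)amino amide of compound 2. The position does not give a single outcome on replacement, however: compound 3 gives an actual number, and the comparison with the other low-activity amide is an at least 4.6-fold lower number from compound 2 to compound 3 (0.66 log units; beyond the scatter), which lies beyond the scatter. The entry for compound 2 is a limit, so this last step gives only a minimum size: the limit of > 50000 nM in this assay, at which 1 of the 3 values shown sits.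

The compounds shown leave open whether the low number of compound 1 goes with the terminal dimethylamino group or with the propyl chain that carries it, which a plain butyl chain or a longer chain ending in the same amine would separate. They also leave open which part of the group entering compound 3 goes with its number, a question that a matching amide with a single carboxylic acid or a single methyl ester would address.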